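Swapping the Ring-Nitrogen Substituent of Compound 1

The source may hold more compounds than are shown below. What is called first, only, known or untested is meant among the compounds shown, and "the series" means these compounds.

Compound 1 `NC(=O)c1c(NC(=O)c2ccc(C(F)(F)F)cc2)sc2c1CCN(Cc1ccc(Cl)cc1Cl)C2` carries a 2,4-dichlorobenzyl group on an amine nitrogen in a ring. In a functional assay on HeLa cells (Homo sapiens) for antiproliferative activity, with a stated time of 24 h (on this read-out higher numbers stand for weaker inhibition and lower numbers for stronger inhibition), compound 1 gives only a limit, > 50000 nM, so its place on the scale is not a number (the limit of > 50000 nM in this assay, at which 1 of the 2 values shown sits). Compound 2 `NC(=O)c1c(NC(=O)c2cccc([N+](=O)[O-])c2)sc2c1CCN(Cc1ccc(Cl)cc1Cl)C2` differs from compound 1 in the aryl group on the carbonyl carbon, and in this assay compound 2 gives 33000 nM; the step of an at least 1.5-fold lower number from compound 1 to compound 2 (0.18 log units; that floor lies within the scatter) is the only one measured, and it concerns the carbonyl side of the shared core, not the ring nitrogen. Compound 3 `NC(=O)c1c(NC(=O)c2ccc(C(F)(F)F)cc2)sc2c1CCN(C(=S)Nc1ccccc1Cl)C2` is not yet measured; it differs from compound 1 by a group of 10 heavy atoms (7 carbon, 1 nitrogen, 1 sulfur, 1 chlorine; one six-membered aromatic ring of carbon only) in place of a group of 9 heavy atoms (7 carbon, 2 chlorine; one six-membered aromatic ring of carbon only), on an amine nitrogen in a ring. Within the data shown here, no measured step touches this position, so no shift beyond the scatter is expected in this assay, and the step of a number no higher from compound 1 to compound 3 (the limit leaves the size open) is an estimate only. Compound 3 is therefore expected to give about 50000 nM in this assay, with a likely range from 15000 nM to 150000 nM, and a fair chance that only a limit is reported again.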

Compound 3, half-maximal inhibitory concentration: 44000 nM
Compound 3: the middle estimate sits 1.1-fold (0.06 log units) above what was measured; low and high end bracket the measured number.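

Among these compounds, compound 3 provides the first measured step on an amine nitrogen in a ring, and in this assay that step is an at least 1.1-fold lower number from compound 1 to compound 3 (0.05 log units; that floor lies within the scatter). Replacing 2,4-dichlorobenzyl with a group carrying 1 hydrogen-bond donor, 1 hydrogen-bond acceptor and 1 double bond outside aromatic rings therefore gives a measured number, 44000 nM for compound 3, but shows no floor beyond the scatter. The value for compound 1 is only a limit, so the true size of this step cannot be read: the limit of > 50000 nM in this assay, at which 1 of the 3 values shown sits.

The compounds shown leave open whether a smaller acetyl group or a chain ending in an amine on this nitrogen would shift the number beyond the scatter. They also leave open how the 3-nitrophenyl group on the carbonyl carbon would behave alongside the group in compound 3.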